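Chlorine Joins the Methoxyphenyl Ring

The source may hold more compounds than are shown below. What is called first, only, known or untested is meant among the compounds shown, and "the series" means these compounds.

Compound 3 `CCC1=C(O)c2c(oc(-c3ccccc3OC)cc2=O)C(CC)(CC)C1=O` is tested in a functional assay on KBVIN cells (Homo sapiens) for antiproliferative activity, read by sulforhodamine B assay, with a stated time of 3 days (a higher number here means that more compound is needed for the effect, a lower number that less compound is needed), where compound 3 gives 3.26 uM. Among the three measured compounds it stands second highest. Compound 2 `CCC1=C(O)c2c(oc(-c3ccc(F)cc3)cc2=O)C(CC)(CC)C1=O` gives 1.85 uM, and the step of a 1.8-fold higher number from compound 2 to compound 3 (0.25 log units; within the scatter) lies within the scatter. Compound 1 `CCC1=C(O)c2c(oc(-c3ccc(Br)cc3)cc2=O)C(CC)(CC)C1=O` gives 15.7 uM, and the step of a 4.8-fold lower number from compound 1 to compound 3 (0.68 log units; beyond the scatter) lies beyond it. The new compound 4 `CCC1=C(O)c2c(oc(-c3ccc(OC)c(Cl)c3)cc2=O)C(CC)(CC)C1=O` differs from compound 3 in one place: 3-chloro-4-methoxyphenyl in place of 2-methoxyphenyl on an aromatic carbon. Among the compounds with values here, two measured steps bear on this change. The step of an 8.5-fold lower number from compound 1 to compound 2 (0.93 log units; beyond the scatter) shows that exchanging one halogen for another moved the number beyond the scatter, and the step of a 4.8-fold lower number from compound 1 to compound 3 (0.68 log units; beyond the scatter) shows that a methoxyphenyl without a halogen sits well below the bromo compound. Compound 4 carries both a halogen and a methoxy group, so a shift back toward the higher number of compound 1 is plausible, though of uncertain size. Compound 4 is therefore expected to give 5.5 uM, within a range of 1.8 uM to 16 uM. The expected step is a 1.7-fold higher number from compound 3 to compound 4 (0.23 log units; within the scatter), which may still fall within the scatter.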

Compound 4, concentration for half-maximal effect: 1.37 uM
Beside the measured number, compound 4's estimate is 4.0-fold (0.60 log units) above it, and the stated range ends above it.
By their numbers in this assay, from the lowest: compounds 4, 2 and 3 (each within the scatter of the next, the first and the last beyond it); then compound 1.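

In this assay, the 3-chloro-4-methoxyphenyl group at this position, next to the ring oxygen, gives a 2.4-fold lower number from compound 3 to compound 4 (0.38 log units; beyond the scatter), so adding a chlorine while changing the methoxyphenyl pattern does not carry the number toward the bromo compound, as an 11-fold lower number from compound 1 to compound 4 (1.06 log units; beyond the scatter) confirms. The same group also gives a 1.4-fold lower number from compound 2 to compound 4 (0.13 log units; within the scatter), which lies within the scatter, so a ring bearing both chlorine and methoxy cannot be told apart here from the 4-fluorophenyl ring. No measurement is available that would explain these steps. The change brings in the chlorine and relocates the methoxy group in a single step, so the compounds shown cannot separate the two contributions. Going by these compounds, how an amine or a carboxylic acid on this ring would read also remains open.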